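A few compounds are considered here, and "the series" means these few. Any claim that something is new, unique, unknown or untested is made for them only; others in the source may bear on it.

In an ADME assay for permeability, using PAMPA, with a stated time of 4 h, at pH 5.5 (on this read-out lower numbers stand for lower permeability and higher numbers for higher permeability), compound 1 `NCCCCN(C[C@H]1Cc2ncccc2CN1)[C@H]1CCCc2cccnc21` gives 17 nm/s, compound 2 `CCN(CC)CCCCN(C[C@H]1Cc2ncccc2CN1)[C@H]1CCCc2cccnc21` gives 3 nm/s and compound 3 `CN(CCCCN(C[C@H]1Cc2ncccc2CN1)[C@H]1CCCc2cccnc21)C1CCC(F)(F)CC1` gives 15 nm/s. Compound 3 therefore belongs to the upper pair of these three numbers, with no real separation inside that pair: a 1.1-fold lower number from compound 1 to compound 3 (0.05 log units; within the scatter). The remaining gap, a 5.0-fold higher number from compound 2 to compound 3 (0.70 log units; beyond the scatter), is modest but beyond the scatter.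

The next structure is compound 4 `c1cnc2c(c1)CN[C@@H](CN(CCCC1CCNCC1)[C@H]1CCCc3cccnc31)C2`, and the change is a group of 6 heavy atoms (5 carbon, 1 nitrogen; one six-membered non-aromatic ring with 1 hetero atom) in place of a group of 11 heavy atoms (8 carbon, 1 nitrogen, 2 fluorine; one six-membered non-aromatic ring of carbon only), on a saturated chain carbon, three bonds along the chain from an amine nitrogen. The closest evidence comes from the measured steps at the end of the chain. One of these, a 5.7-fold lower number from compound 1 to compound 2 (0.75 log units; beyond the scatter), is modest, while a 1.1-fold lower number from compound 1 to compound 3 (0.05 log units; within the scatter) stays within the scatter. Among the measured compounds shown here, none of the measured compounds carries a piperidin-4-yl group, and three numbers give no firm trend. A step beyond the scatter in this assay is therefore not expected. The expected outcome is a small fall, a 1.4-fold lower number from compound 3 to compound 4 (0.13 log units; within the scatter). For compound 4 the estimated value is 11 nm/s, with an expected range from 4 nm/s to 28 nm/s.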

Compound 4, apparent permeability: 14 nm/s
Estimate against measurement, compound 4: 1.3-fold (0.10 log units) below; low and high end bracket the measured number.
By their numbers in this assay, from the lowest: compound 2; then compounds 4, 3 and 1 (each within the scatter of the next).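

In this assay, piperidin-4-yl on a saturated chain carbon, three bonds along the chain from an amine nitrogen, shows no separation from the group of 11 heavy atoms it replaces, with a 1.1-fold lower number from compound 3 to compound 4 (0.03 log units; within the scatter), or from aminomethyl, with a 1.2-fold lower number from compound 1 to compound 4 (0.08 log units; within the scatter). Only diethylamino stands apart, with a 4.7-fold higher number from compound 2 to compound 4 (0.67 log units; beyond the scatter), so among these four chain ends a ring with a hetero atom sits in the upper set and the single low number belongs to that one group. Nothing given here accounts for why that one group stands apart while the other three chain ends do not.

From the compounds shown here alone, it remains open whether the low number is particular to diethylamino or would also appear with a dimethylamino or pyrrolidine end. Going by these compounds, how a morpholine or a carboxylic acid would read at this place is equally open.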